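Isobutyl in place of isopropyl on a sulfur

A few compounds are considered here, and "the series" means these few. Any claim that something is new, unique, unknown or untested is made for them only; others in the source may bear on it.

Measured in an ADME assay on Vero cells (Chlorocebus sabaeus) for cytotoxicity, read by MTT assay, with a stated time of 72 h (a higher number here means a weaker inhibitor, a lower number a stronger inhibitor), as follows
compound 1 `CCC[S+]([O-])CCCCN=C=S` gives 5640 nM
compound 2 `CCCC[S+]([O-])CCCCN=C=S` gives 5150 nM
compound 3 `CC(C)[S+]([O-])CCCCN=C=S` gives 10400 nM

Compound 3 stands at 10400 nM and its place among the three is mixed. Two measured steps end at it (a 1.8-fold higher number from compound 1 to compound 3 (0.27 log units; within the scatter)) and (a 2.0-fold higher number from compound 2 to compound 3 (0.31 log units; beyond the scatter)), so it stands clear of only one of the others. The unmeasured compound 4 `CC(C)C[S+]([O-])CCCCN=C=S` has isobutyl in place of isopropyl on a sulfur. Going by the values given here, no measured compound carries isobutyl, so no step measures this change directly. The nearest guides are those two steps, read in reverse, together with the change from propyl to butyl (a 1.1-fold lower number from compound 1 to compound 2 (0.04 log units; within the scatter)), which stayed within the scatter. If isobutyl tracks those open chains, the number should move toward compound 1 at 5640 nM and compound 2 at 5150 nM. Only a small fall is therefore expected, and the estimated change stays within the scatter (a 1.6-fold lower number from compound 3 to compound 4 (0.20 log units; within the scatter)). Compound 4 is estimated at 6500 nM (expected range from 3800 nM to 11000 nM).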

Compound 4, half-maximal inhibitory concentration: 4980 nM
The estimate for compound 4 lay 1.3-fold (0.12 log units) above the measured number; the measured number falls inside the stated range.
By their numbers in this assay, from the lowest: compounds 4, 2, 1 and 3 (each within the scatter of the next, the first and the last beyond it).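

In this assay, isobutyl on this sulfur gives a modest drop from isopropyl, a 2.1-fold lower number from compound 3 to compound 4 (0.32 log units; beyond the scatter), so a branched group here does not by itself carry the higher number. Isobutyl instead sits with the open chains, with a 1.0-fold lower number from compound 2 to compound 4 (0.01 log units; within the scatter) and a 1.1-fold lower number from compound 1 to compound 4 (0.05 log units; within the scatter), and so compound 3 alone stands apart, clearly from compound 2 and compound 4 though not from compound 1. No evidence is available that accounts for this difference between the two branched groups.

The compounds shown leave open where a cyclopropyl or benzyl group, or a chain longer than butyl, on this sulfur would fall in this assay. They also leave open whether an amine or a carboxylic acid at the end of that chain would stay with the open chains or move away from them.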